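This account rests on a few compounds, and the source may have more. Where it says the series, first, only, none or still open, it means among the compounds named here.

Measured compounds in a functional assay on MGC-803 cells (Homo sapiens) for inhibition, read by sulforhodamine B assay, with a stated time of 72 h, tested at 10 uM; on this read-out lower numbers stand for less inhibition and higher numbers for more inhibition at the one concentration tested (going by the name of the read-out):
compound 1, `Cc1cc(Nc2ccc(C(=O)/C=C/c3cccc(Br)n3)cc2)n2nc(SCc3ccccc3)nc2n1`: 90.2%
compound 2, `Cc1cc(Nc2ccc(C(=O)/C=C/c3cccc(Br)n3)cc2)n2nc(SCc3ccc(F)cc3)nc2n1`: 93.3%
compound 3, `Cc1cc(Nc2ccc(C(=O)/C=C/c3cccc(Br)n3)cc2)n2nc(SCc3ccccc3[N+](=O)[O-])nc2n1`: 92.3%

The three numbers sit close together. Compound 3 differs from compound 2 by a number 1 percentage points lower from compound 2 to compound 3 (within the scatter) and from compound 1 by a number 2.1 percentage points higher from compound 1 to compound 3 (within the scatter), so nothing separates it from either neighbour beyond the scatter.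

Compound 4, `Cc1cc(Nc2ccc(C(=O)/C=C/c3cccc(Br)n3)cc2)n2nc(SCc3ccc(C(F)(F)F)cc3)nc2n1`, has not yet been measured. It differs from compound 3 in one place: 4-(trifluoromethyl)phenyl in place of 2-nitrophenyl on a saturated chain carbon bound to a sulfur.

Among the measured compounds shown here, three measured steps bear on this change, all at the same saturated chain carbon bound to a sulfur. Fluoro in place of hydrogen on an aromatic carbon gave a number 3.1 percentage points higher from compound 1 to compound 2 (within the scatter); nitro in place of hydrogen gave a number 2.1 percentage points higher from compound 1 to compound 3 (within the scatter); and 2-nitrophenyl in place of 4-fluorophenyl gave a number 1 percentage points lower from compound 2 to compound 3 (within the scatter). Every variation of the benzyl group so far has left the read-out where it was. Compound 4 is therefore expected to show no step beyond the scatter, an estimated a number 1.3 percentage points lower from compound 3 to compound 4 (within the scatter). Compound 4 is estimated at 91%, with a range from 83% to 97%.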

Compound 4, a percentage reported as inhibition, at one concentration (the size of the read-out at that concentration, not a potency): 96.6%
Compound 4: the middle estimate sits 5.6 percentage points below what was measured; the measured number falls inside the stated range.
By their numbers in this assay, from the lowest: compounds 1, 3, 2 and 4 (each within the scatter of the next).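

At the saturated chain carbon bound to a sulfur, the 4-(trifluoromethyl)phenyl group also leaves the read-out of this assay unmoved: the change from 2-nitrophenyl gives a number 4.3 percentage points higher from compound 3 to compound 4 (within the scatter), trifluoromethyl in place of fluoro gives a number 3.3 percentage points higher from compound 2 to compound 4 (within the scatter), and trifluoromethyl in place of hydrogen gives a number 6.4 percentage points higher from compound 1 to compound 4 (within the scatter). The earlier compounds shown here showed this only for fluoro and nitro, so the finding now extends to a third substituent, one that carries no hydrogen-bond acceptors, unlike the 2-nitrophenyl group it replaces. Nothing available here offers an explanation for this insensitivity.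

Going by these compounds, what an amine or a carboxylic acid on this phenyl ring would do remains open, as does a longer chain in place of the benzyl group. On these data alone, with a single concentration for each compound, any differences in potency among them also remain unknown.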